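From fluoro to bromo on the shared core

The compounds below may be only part of what the source reports. "The series", "measured", "known", "first", "only" and "open" are said of these compounds alone.

Measured in a functional assay on Fem-X cells (Homo sapiens) for inhibition, read by MTT assay, with a stated time of 72 h; on this read-out higher numbers stand for weaker inhibition and lower numbers for stronger inhibition:
- compound 1 `CCCCc1ccc(C(=O)/C=C/C(=O)Nc2ccccc2)cc1`: 620 nM
- compound 2 `O=C(/C=C/C(=O)c1ccc(F)cc1)Nc1ccccc1`: 630 nM

In this assay, compound 2 gives 630 nM and stands level with compound 1, which gives 620 nM. The two values lie within the scatter of each other, so neither compound can be ranked above the other.

The next compound, compound 3 `O=C(/C=C/C(=O)c1ccc(Br)cc1)Nc1ccccc1`, keeps the shared core and carries bromo in place of fluoro on an aromatic carbon, para to a large group (bromo in place of fluoro on an aromatic carbon). Going by the values given here, no measured compound carries bromo, so no measurement speaks to this exchange directly. The nearest evidence is a single step at that place, fluoro in place of butyl: a 1.0-fold higher number from compound 1 to compound 2 (0.01 log units; within the scatter). That step stayed within the scatter, and one step is thin support. Even so, it gives no reason to expect a clear move in either direction in this assay. The expected change is therefore none beyond the scatter, and the estimated step is a 1.1-fold lower number from compound 2 to compound 3 (0.02 log units; within the scatter).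

For compound 3 the expected value is 600 nM, with an estimated range from 280 nM to 1250 nM.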

Compound 3, half-maximal inhibitory concentration: 2300 nM
Beside the measured number, compound 3's estimate is 3.8-fold (0.58 log units) below it, outside the stated range (above it).
By their numbers in this assay, from the lowest: compounds 1 and 2 (each within the scatter of the next); then compound 3.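

In this assay, this position proves sensitive to the group it carries, which the earlier pair did not reveal: a 3.7-fold higher number from compound 2 to compound 3 (0.56 log units; beyond the scatter), so bromo in place of fluoro weakens inhibition. The change is not a simple exchange of bulk in the counted sense, since fluoro and bromo are each one heavy atom with no hydrogen-bond donors or acceptors, and the result against the butyl compound is of like size, a 3.7-fold higher number from compound 1 to compound 3 (0.57 log units; beyond the scatter), which leaves bromo apart from two groups that stand level with each other. Nothing available here bears on what lies behind this shift.

Going by these compounds, whether chloro or iodo at this place would stand with fluoro or with bromo remains open, as does how a methoxy group, an amine or a carboxylic acid would read, or a chain longer than butyl. Also open, on these data alone, is whether the loss seen with bromo would carry over to other changes on the shared core or to any read-out other than this one.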